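This account rests on a few compounds, and the source may have more. Where it says the series, first, only, none or still open, it means among the compounds named here.

Compound 3 `Cc1ccc2nc(-c3ccccc3N(C)C)[nH]c(=O)c2c1` stands at the top of the three numbers in a functional assay on HeLa cells (Homo sapiens) for cytotoxicity, read by MTT assay, with a stated time of 2 days (a lower number here means a stronger inhibitor, a higher number a weaker inhibitor), where compound 3 gives 14000 nM. Compound 1 `Cc1ccc2nc(-c3ccccc3C(F)(F)F)[nH]c(=O)c2c1` gives 2450 nM in this assay, and compound 2 `CCN(CC)c1ccc2nc(-c3ccccc3N(C)C)[nH]c(=O)c2c1` gives 70 nM. Compound 4 `Cc1ccc2nc(-c3ccccc3OC(F)(F)F)[nH]c(=O)c2c1` differs from compound 3 in one place: trifluoromethoxy in place of dimethylamino on an aromatic carbon. The measured step that bears on this is a 5.7-fold higher number from compound 1 to compound 3 (0.76 log units; beyond the scatter), read here in reverse, since the group that enters resembles the trifluoromethyl carried by compound 1; the step of a 200-fold higher number from compound 2 to compound 3 (2.30 log units; beyond the scatter) changes a different part of the core and offers no guide. A modest fall in number is therefore expected, a 4.0-fold lower number from compound 3 to compound 4 (0.60 log units; beyond the scatter). For compound 4 the estimate in this assay is 3500 nM, within 1200 nM to 10000 nM.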

Compound 4, half-maximal inhibitory concentration: 850 nM
Estimate against measurement, compound 4: 4.1-fold (0.61 log units) above; the whole stated range lies above it.
By their numbers in this assay, from the lowest: compound 2; then compound 4; then compound 1; then compound 3.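

At this aromatic carbon the choice of group matters more than compound 1 suggested: in this assay, trifluoromethoxy in place of dimethylamino gives a 16-fold lower number from compound 3 to compound 4 (1.22 log units; beyond the scatter). Trifluoromethoxy is also not interchangeable with trifluoromethyl, as replacing one with the other gives a 2.9-fold lower number from compound 1 to compound 4 (0.46 log units; beyond the scatter), so on this core the numbers rise from trifluoromethoxy through trifluoromethyl to dimethylamino. No measurement available here explains this order.

The compounds shown leave open how a carboxylic acid or a longer alkoxy chain at this carbon would compare. They also leave open whether trifluoromethoxy would keep its lower number on the core of compound 2, which carries diethylamino.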